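Extending the amine on compound 2: expected cytotoxicity

The compounds below may be only part of what the source reports. "The series", "measured", "known", "first", "only" and "open" are said of these compounds alone.

Compound 2 `CCCCOC(=O)Nc1cc2nc(C3CCCCC3)[nH]c2cc1N(C)C` carries a butoxycarbonylamino group and a dimethylamino group on its shared core. In an ADME assay on Vero cells (Chlorocebus sabaeus) for cytotoxicity, read by resazurin assay, with a stated time of 3 days (a lower number here means a stronger inhibitor, a higher number a weaker inhibitor), compound 2 gives > 100 ug/mL, which is a limit of the assay and not a number. Going by the values given here, its only measured neighbour is compound 1 `COc1ccc(C(=O)Nc2cc3nc(C4CCCCC4)[nH]c3cc2N(C)C)cc1`, in which 4-methoxyphenyl stands on the carbonyl carbon where compound 2 has butoxy. In this assay compound 1 gives > 100 ug/mL, again a limit and not a number. The step that the two limits leave unreadable from compound 1 to compound 2 is therefore not readable, and the limit of > 100 ug/mL in this assay, at which 2 of the 2 values shown sit, sums up what the two values show: both sit at the limit. Compound 3 `CCCCOC(=O)Nc1cc2nc(C3CCCCC3)[nH]c2cc1N(CC)CCN(C)C` is not yet measured; it differs from compound 2 by (2-(dimethylamino)ethyl)(ethyl)amino in place of dimethylamino on an aromatic carbon. Among the compounds with values here, no measured step involves a change of this kind, and the one measured step is unreadable, so the data give no direction for it. The expectation rests on compound 2 standing at the limit: compound 3 is expected to stay weak, with an expected step of a number no higher from compound 2 to compound 3 (the limit leaves the size open) that is no size beyond the scatter. Compound 3 is thus estimated at 100 ug/mL, in a range from 30 ug/mL to 300 ug/mL.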

Compound 3, half-maximal inhibitory concentration: > 100 ug/mL
Compound 3 was reported as a limit; the forecaster's own chance of this, stated with the estimate: 60%; the middle value lies on the limit itself.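

In this assay compound 3 gives > 100 ug/mL, a limit of the assay and not a number. Going by these compounds alone, compound 2 and compound 3 both stand at a limit, so no step between them can be read. The compounds shown leave open whether any change on the shared core would yield a readable value in this assay: the limit of > 100 ug/mL in this assay, at which 3 of the 3 values shown sit.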